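Oxolan-3-yl ether in place of methoxy: series notes

A few compounds are considered here, and "the series" means these few. Any claim that something is new, unique, unknown or untested is made for them only; others in the source may bear on it.

Antiproliferative activity is read in a functional assay on PC-3 cells (Homo sapiens) for antiproliferative activity, read by MTT assay, with a stated time of 72 h; on this read-out higher numbers stand for weaker inhibition and lower numbers for stronger inhibition. Measured so far:

compound 1, `C=CC(=O)Nc1cc2c(N3CCc4ccccc43)ncnc2cc1OC`: compound 1 gives 5940 nM
compound 2, `C=CC(=O)Nc1cc2c(N3CCc4ccccc43)ncnc2cc1O[C@@H]1CCOC1`: compound 2 gives 2710 nM
compound 3, `COc1cc2ncnc(N3CCCc4ccccc43)c2cc1NC(=O)C=C(C)C`: compound 3 gives 6130 nM

Compound 1 and compound 2 share a core and differ in one place: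

oxolan-3-yl in place of methyl on an oxygen on an aromatic ring

This change gives a 2.2-fold lower number from compound 1 to compound 2 (0.34 log units; beyond the scatter) in this assay, a modest step that lies beyond the usual scatter.

Compound 3 carries a different core; the difference between the core of compound 3 and the core of compound 1 is not broken down here. In this assay compound 3 and compound 1 give numbers that lie within the scatter of each other, so no order between them is claimed.

Compound 4, `CC(C)=CC(=O)Nc1cc2c(N3CCCc4ccccc43)ncnc2cc1O[C@@H]1CCOC1`, has not been measured. It differs from compound 3 in one place:

oxolan-3-yl in place of methyl on an oxygen on an aromatic ring

The place line for this change is the same, word for word, as for the change from compound 1 to compound 2, so the change is the same one, made on the core of compound 3. Among the measured compounds shown here, the expectation for compound 4 rests on the one earlier instance of this change, because a 2.2-fold lower number from compound 1 to compound 2 (0.34 log units; beyond the scatter) is the only measured step of this kind, and on the value of compound 3, 6130 nM. With a single precedent and a different core, the step is estimated with wide margins: the expected step is a 2.2-fold lower number from compound 3 to compound 4 (0.34 log units; beyond the scatter). In this assay compound 4 is estimated at 2800 nM, expected to fall between 1200 nM and 6500 nM.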

Compound 4, half-maximal inhibitory concentration: 9020 nM
Compound 4: middle estimate off by 3.2-fold (0.51 log units), on the low side; the measured number lies above the stated range.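

In this assay, among the compounds shown here, exchanging methoxy for (oxolan-3-yl)oxy on the core of compound 3 gives a 1.5-fold higher number from compound 3 to compound 4 (0.17 log units; within the scatter), so on this core the exchange produces no step that can be told from the scatter. The same exchange on the core of compound 1 does give a step beyond the scatter, and the two results do not agree, which shows that the step seen on one core cannot be carried over unchanged to the other in this series: the same change on two cores in this assay, a 2.2-fold lower number (0.34 log units; beyond the scatter) from compound 1 to compound 2 and a 1.5-fold higher number (0.17 log units; within the scatter) from compound 3 to compound 4, 3.2-fold (0.51 log units) apart, beyond the scatter of two such steps. These two pairs do not show which part of the difference between the cores goes with the different outcome, they do not show that the exchange is harmful on the core of compound 3, and they set no rule for any further core.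

Still open is how the oxolan-3-yl ether behaves on a core that combines features of the two cores shown, which could help separate the contribution of each part of the core. Also open, going by these compounds, are the opposite configuration at the defined stereocentre and other ether groups on the same oxygen, such as a longer chain ending in an amine.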